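This account rests on a few compounds, and the source may have more. Where it says the series, first, only, none or still open, it means among the compounds named here.

Measured so far in a toxicity assay on MT4 cells (Homo sapiens) for cytotoxicity, read by MTT assay; a higher number here means that more compound is tolerated, a lower number that less compound is tolerated:
- compound 1 `Cc1cc(-c2cccc(F)c2)cc(C)c1Oc1cc(N)nc(Nc2ccc(C#N)cc2)n1`: 24700 nM
- compound 2 `Cc1cc(-c2ccc(F)cc2)cc(C)c1Oc1cc(N)nc(Nc2ccc(C#N)cc2)n1`: 23100 nM
- compound 3 `COc1cccc(-c2cc(C)c(Oc3cc(N)nc(Nc4ccc(C#N)cc4)n3)c(C)c2)c1`: 19300 nM

In this assay, compound 3 gives 19300 nM, and no order can be drawn among the three compounds. Its value lies within the scatter of both others: a 1.3-fold lower number from compound 1 to compound 3 (0.11 log units; within the scatter), and a 1.2-fold lower number from compound 2 to compound 3 (0.08 log units; within the scatter).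

The next compound is compound 4 `Cc1cc(-c2ccc(C#N)cc2)cc(C)c1Oc1cc(N)nc(Nc2ccc(C#N)cc2)n1`, which carries 4-cyanophenyl in place of 3-methoxyphenyl on an aromatic carbon.

All three measured steps exchange one substituted phenyl for another at this same place, so all of them bear on the change. Besides the two above, there is a 1.1-fold lower number from compound 1 to compound 2 (0.03 log units; within the scatter). None of them leaves the scatter, but three compounds make a narrow base, and 4-cyanophenyl has not been measured at this place. A step beyond the scatter in either direction therefore cannot be excluded, though none is expected, and the range is kept wider than the measured spread.

The expected step is a 1.1-fold lower number from compound 3 to compound 4 (0.03 log units; within the scatter), which would not go beyond the scatter.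

For compound 4 the estimated value is 18000 nM, with an expected range of 8000 nM to 35000 nM.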

Compound 4, half-maximal cytotoxic concentration: 18100 nM
Compound 4: the middle estimate sits 1.0-fold (0.00 log units) below what was measured; measured number inside the range.
By their numbers in this assay, from the lowest: compounds 4, 3, 2 and 1 (each within the scatter of the next).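

In this assay, the place meta to two methyl groups now holds 4-cyanophenyl, the first group there with a triple bond outside aromatic rings, and the number stays within the scatter of all three earlier compounds (a 1.1-fold lower number from compound 3 to compound 4 (0.03 log units; within the scatter)) (a 1.3-fold lower number from compound 2 to compound 4 (0.11 log units; within the scatter)) (a 1.4-fold lower number from compound 1 to compound 4 (0.14 log units; within the scatter)). The 3-fluorophenyl, 4-fluorophenyl, 3-methoxyphenyl and 4-cyanophenyl groups therefore give no order at this place, so across these four compounds the tolerated concentration does not separate them by the substituent on the phenyl, whether fluoro, methoxy or cyano. Nothing available here bears on why these numbers stay together.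

Still open, as far as these compounds go, is whether this holds once the substituted phenyl gives way to something of another kind, such as a phenyl carrying a carboxylic acid or an aminomethyl group, or a longer alkyl chain in place of the ring. The compounds shown also leave open whether the same exchanges stay within the scatter on a different core, since all four share one core and vary only at this place.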